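Removing one methyl from the most active compound

This account rests on a few compounds, and the source may have more. Where it says the series, first, only, none or still open, it means among the compounds named here.

Measured so far in a functional assay on SK-MEL-5 cells (Homo sapiens); on this read-out lower numbers stand for stronger inhibition of growth and higher numbers for weaker inhibition of growth:
- compound 1 `Cc1ccnc2nc(-c3ccc(Cl)cc3)cc(O)c12`: 3470 nM
- compound 2 `COc1cccc(-c2cc(O)c3cc(C)cnc3n2)c1`: 25.7 nM
- compound 3 `COc1ccccc1-c1cc(O)c2c(C)ccnc2n1`: 22400 nM

Compound 2 has the lowest number of the three. Compound 1 is its nearest neighbour and compound 3 lies furthest away, and both gaps are well beyond the usual scatter of repeated measurements.

The next compound to be tested is compound 4 `COc1cccc(-c2cc(O)c3cccnc3n2)c1`. It is compound 2 with hydrogen in place of methyl on an aromatic carbon.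

Within the data shown here, no two measured compounds differ in only one place, so there is no direct precedent for the size of this step in this assay. Compound 2, at 25.7 nM, already sits at the low end of the numbers seen so far, so a rise looks more likely than a further fall. The expected change is a 5.8-fold higher number from compound 2 to compound 4 (0.77 log units; beyond the scatter), a moderate weakening that is probably beyond the scatter, though this is only an estimate. For compound 4 the estimated value is 150 nM, with an expected range from 25 nM to 1000 nM.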

Compound 4, concentration for 50% growth inhibition: 53.7 nM
Compound 4: middle estimate off by 2.8-fold (0.45 log units), on the high side, within the range that was stated.
By their numbers in this assay, from the lowest: compound 2; then compound 4; then compound 1; then compound 3.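

Among these compounds, this is the first step in this assay that changes only one place, and it comes to a 2.1-fold higher number from compound 2 to compound 4 (0.32 log units; beyond the scatter), a modest rise that lies beyond the scatter. The methyl on this aromatic carbon, para to a fused ring, therefore adds to the inhibition of growth but is not required, since compound 4 , which has only hydrogen there, still gives 53.7 nM in the same assay. The data offer no measurement that could explain the size of this step.

On these data alone, with only hydrogen and methyl compared at this position, it remains open whether a longer chain such as ethyl, or an amine, would give a lower or a higher number. As far as these compounds go, it is also open whether removing this methyl would have a similar effect in a compound with a different group on the shared core.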